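A few compounds are considered here, and "the series" means these few. Any claim that something is new, unique, unknown or untested is made for them only; others in the source may bear on it.

Of the compounds shown here, three built on one shared core have been tested in a functional assay on HepG2 cells (Homo sapiens) for antiproliferative activity, read by MTT assay, with a stated time of 48 h; on this read-out higher numbers stand for weaker inhibition and lower numbers for stronger inhibition. Compound 1 `Cc1ccc(-c2nc(NN)c3cc(Cl)ccc3n2)cc1` gives 4.17 ug/mL. Compound 2 `Cc1ccc(-c2nc(NC(=O)c3ccccc3)c3cc(Cl)ccc3n2)cc1` gives 17.5 ug/mL, and compound 3 `Cc1ccc(-c2nc(SCc3ccccc3)c3cc(Cl)ccc3n2)cc1` gives 18.4 ug/mL. Compound 3 thus carries the highest of the three numbers: the step of a 1.1-fold higher number from compound 2 to compound 3 (0.02 log units; within the scatter) lies within the scatter, whereas a 4.2-fold higher number from compound 1 to compound 2 (0.62 log units; beyond the scatter) and a 4.4-fold higher number from compound 1 to compound 3 (0.64 log units; beyond the scatter) lie beyond it. Compound 4 `Cc1ccc(-c2nc(SCC#N)c3cc(Cl)ccc3n2)cc1` has not yet been measured; it differs from compound 3 by cyano in place of phenyl on a saturated chain carbon bound to a sulfur. Within the data shown here, no measured step alters this part of the side chain, and the only step that reshaped the side chain, a 1.1-fold higher number from compound 2 to compound 3 (0.02 log units; within the scatter), stayed within the scatter. A step of a 1.0-fold lower number from compound 3 to compound 4 (0.01 log units; within the scatter) is therefore expected, not clearly beyond the scatter. Compound 4 is estimated at 18 ug/mL, with a range from 8 ug/mL to 40 ug/mL.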

Compound 4, half-maximal inhibitory concentration: 4.37 ug/mL
Compound 4: middle estimate off by 4.1-fold (0.61 log units), on the high side; measured number below the stated range.
By their numbers in this assay, from the lowest: compounds 1 and 4 (each within the scatter of the next); then compounds 2 and 3 (each within the scatter of the next).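

In this assay, a sulfanyl side chain does not by itself set the number: the group on the saturated chain carbon bound to a sulfur counts, with cyano in place of phenyl giving a 4.2-fold lower number from compound 3 to compound 4 (0.62 log units; beyond the scatter) in this series. The (cyanomethyl)sulfanyl group also separates from benzamido (a 4.0-fold lower number from compound 2 to compound 4 (0.60 log units; beyond the scatter)) but not from aminoamino (a 1.0-fold higher number from compound 1 to compound 4 (0.02 log units; within the scatter)), so a side chain without that aminoamino group can read like compound 1. How a methyl, a longer chain or an amine would read at this place stays open, and nothing shown explains the difference between cyano and phenyl.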